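Ester chain shortening on the retinoid amide series

The source may report more compounds than this note shows. Statements on the series, on what has been measured and on what is new or still open speak of the compounds shown alone.

Compound 1 `CCCC(CCC)C(=O)OCCCOC(=O)c1ccc(C(=O)Nc2ccc3c(c2)C(C)(C)CCC3(C)C)cc1` stands at a limit in a functional assay on NB-4 cells (Homo sapiens) for inhibition, read by MTT assay, with a stated time of 48 h; a lower number here means a stronger inhibitor, a higher number a weaker inhibitor: compound 1 gives > 1000000 nM, a limit of the assay and not a number, as the limit of > 1000000 nM in this assay, at which 1 of the 2 values shown sits, records. Among the measured compounds shown here, compound 2 `Cc1cc2c(cc1C(=O)c1ccc(C(=O)OCCOC(=O)c3ccc(C(=O)Nc4ccc5c(c4)C(C)(C)CCC5(C)C)cc3)cc1)C(C)(C)CCC2(C)C`, the only other compound measured, gives 67000 nM in this assay. Compound 3 `CCCC(=O)OCCCOC(=O)c1ccc(C(=O)Nc2ccc3c(c2)C(C)(C)CCC3(C)C)cc1` differs from compound 1 by propyl in place of 1-propylbutyl on a carbonyl carbon. For the measured compounds named here, no measured step bears on this change, so in this assay no shift beyond the scatter is expected and a limit is likely to recur. Compound 3 is estimated at 1000000 nM, within 200000 nM to 5000000 nM. The step of a number no higher from compound 1 to compound 3 (the limit leaves the size open) is expected to be none.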

Compound 3, half-maximal inhibitory concentration: 5750 nM
Beside the measured number, compound 3's estimate is 170-fold (2.24 log units) above it; the whole stated range lies above it.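

Among the compounds shown here, on the carbonyl carbon of this ester, the group carried there matters in this assay: propyl in place of 1-propylbutyl gives an at least 170-fold lower number from compound 1 to compound 3 (2.24 log units; beyond the scatter), the only measured step at this position. Compound 3 therefore gives a readable value of 5750 nM on this scaffold. Compound 1 stands at a limit and not a number, so the full size of the step stays open: the limit of > 1000000 nM in this assay, at which 1 of the 3 values shown sits.

The change alters both chain length and branching, and the compounds shown do not separate the two. On these data alone, how a straight pentyl chain, or an amine in place of propyl, would read remains open.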